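A few compounds are considered here, and "the series" means these few. Any claim that something is new, unique, unknown or untested is made for them only; others in the source may bear on it.

Of the compounds shown here, three from this study have been measured in a functional assay on OVCAR-3 cells (Homo sapiens) for inhibition; a higher number here means a weaker inhibitor of growth, a lower number a stronger inhibitor of growth. Compound 1 has the structure `COc1cc(/C=C/C(=O)c2cccc(-n3cc(-c4ccc(Cl)cc4)[nH]c3=O)c2)cc(OC)c1OC` and in this assay compound 1 gives 2400 nM. Compound 2, `COc1ccc(-c2cn(-c3cccc(C(=O)/C=C/c4ccc(O)c(OC)c4)c3)c(=O)[nH]2)cc1`, gives in this assay 2700 nM. Compound 3, `COc1ccc(-c2cn(-c3cccc(C(=O)/C=C/c4cc(OC)c(OC)c(OC)c4)c3)c(=O)[nH]2)cc1`, gives in this assay 1780 nM. All three numbers lie close together, and none of the three compounds can be singled out from the others.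

Two single changes connect these compounds. Compound 3 and compound 1 differ by chloro in place of methoxy on an aromatic carbon, and this change gave in this assay a 1.3-fold higher number from compound 3 to compound 1 (0.13 log units; within the scatter). Compound 3 and compound 2 differ in their cores by 4-hydroxy-3-methoxyphenyl in place of 3,4,5-trimethoxyphenyl on a double-bonded chain carbon bound to a double-bonded chain carbon, and in this assay the step was a 1.5-fold lower number from compound 2 to compound 3 (0.18 log units; within the scatter).

A fourth compound, compound 4, with the structure `COc1cc(/C=C/C(=O)c2cccc(-n3cc(-c4ccc(Cl)cc4)[nH]c3=O)c2)ccc1O`, has not yet been measured in this assay. Compound 4 differs from compound 2 by chloro in place of methoxy on an aromatic carbon. For the measured compounds named here, this is the same change as the one from compound 3 to compound 1, made on the same place, para to a large group, but on the core of compound 2 rather than the core of compound 3. Because the earlier step was a 1.3-fold higher number from compound 3 to compound 1 (0.13 log units; within the scatter), the step from compound 2 to compound 4 is expected to be of similar size, estimated as a 1.2-fold higher number from compound 2 to compound 4 (0.09 log units; within the scatter). On that basis compound 4 is expected to give in this assay about 3300 nM, with a likely range estimated from 1600 nM to 7000 nM.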

Compound 4, concentration for 50% growth inhibition: 1560 nM
For compound 4 the middle estimate is 2.1-fold (0.33 log units) above the measured one, and the stated range ends above it.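

Chloro in place of methoxy gave in this assay a 1.7-fold lower number from compound 2 to compound 4 (0.24 log units; within the scatter), so on this core the swap of 4-methoxyphenyl to 4-chlorophenyl stays inside the usual scatter. Set beside the same change on the other core, the new step cannot be told apart from the earlier one: the same change on two cores in this assay, a 1.3-fold higher number (0.13 log units; within the scatter) from compound 3 to compound 1 and a 1.7-fold lower number (0.24 log units; within the scatter) from compound 2 to compound 4, 2.3-fold (0.37 log units) apart, within the scatter of two such steps. This shows that the change, carried from one core to the other, behaves alike in the only sense these data allow, since neither step can be separated from the scatter, but it does not show a real effect of the change that travels between cores, and the opposite directions of the two printed steps are no sign that the cores respond differently.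

The compounds shown leave open whether an amine, a carboxylic acid or a longer alkyl chain in the place held by methoxy or chloro would give a step beyond the scatter. They also leave open how the same change would read on a core that carries something other than the 3,4,5-trimethoxyphenyl or 4-hydroxy-3-methoxyphenyl group, for instance a phenyl ring bearing a nitrile.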